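Triazolylmethyl series: aryl swap on the triazole nitrogen

The source may hold more compounds than are shown below. What is called first, only, known or untested is meant among the compounds shown, and "the series" means these compounds.

Measured so far in a functional assay on A549 cells (Homo sapiens) for antiproliferative activity, read by MTT assay, with a stated time of 48 h; a lower number here means a stronger inhibitor, a higher number a weaker inhibitor:
- compound 1 `N#CC1=C(N)Oc2c(N)cc3nc4ccccc4nc3c2C12C(=O)N(Cc1cnnn1-c1cccc(C(F)(F)F)c1)c1ccccc12` gives 5400 nM
- compound 2 `COc1ccccc1-n1nncc1CN1C(=O)C2(C(C#N)=C(N)Oc3c(N)cc4nc5ccccc5nc4c32)c2ccccc21` gives 37500 nM
- compound 3 `CCOc1ccc(-n2nncc2CN2C(=O)C3(C(C#N)=C(N)Oc4c(N)cc5nc6ccccc6nc5c43)c3ccccc32)cc1` sits at the assay limit of > 50000 nM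

Going by the values given here, compound 3 is the only member of the three with no number, just a limit, and the limit of > 50000 nM in this assay, at which 1 of the 3 values shown sits, marks that position. On the numbers shown, compound 1 stands lowest, the step of a 6.9-fold higher number from compound 1 to compound 2 (0.84 log units; beyond the scatter) and the step of an at least 9.2-fold higher number from compound 1 to compound 3 (0.96 log units; beyond the scatter) both run upward beyond the scatter, while an at least 1.3-fold higher number from compound 2 to compound 3 (0.12 log units; that floor lies within the scatter) is bounded only by a floor that sits within the scatter.

Compound 4 `CCc1cccc(CC)c1-n1nncc1CN1C(=O)C2(C(C#N)=C(N)Oc3c(N)cc4nc5ccccc5nc4c32)c2ccccc21` differs from compound 3 in one place: 2,6-diethylphenyl in place of 4-ethoxyphenyl on an aromatic nitrogen. All three measured steps change the group on this same aromatic nitrogen, so they bear directly on this one, but none of them involves a 2,6-diethylphenyl, and compound 3 itself is a limit, so the starting point is not fixed. The measured steps span from a modest rise to a rise of unknown size. The expected step in this assay, an at least 1.6-fold lower number from compound 3 to compound 4 (0.22 log units; that floor lies within the scatter), is therefore downward or none, with wide uncertainty; compound 4 is estimated at 30000 nM, with a range from 7000 nM to 60000 nM.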

Compound 4, half-maximal inhibitory concentration: > 50000 nM
Compound 4: only a limit was reported; the forecaster's own chance of this, stated with the estimate: 40%; middle value at least 1.6-fold (0.22 log units) away from the limit.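

In this assay compound 4 gives > 50000 nM, a limit and not a number, so the step between compound 3 and compound 4 cannot be read. 2,6-Diethylphenyl in place of 3-(trifluoromethyl)phenyl gives an at least 9.2-fold higher number from compound 1 to compound 4 (0.96 log units; beyond the scatter), so all three replacements shown for that group now run upward, including one with no oxygen, while 2,6-diethylphenyl in place of 2-methoxyphenyl gives only an at least 1.3-fold higher number from compound 2 to compound 4 (0.12 log units; that floor lies within the scatter). The assay limit now bounds much of what this position can show: the limit of > 50000 nM in this assay, at which 2 of the 4 values shown sit.

As far as these compounds go, whether 2,6-diethylphenyl and 4-ethoxyphenyl differ at all remains open. Also open, from the compounds shown here alone, is whether an aryl group carrying an amine or a carboxylic acid would reach a reading as low as that of compound 1.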